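Formyl in Place of Methyl on the Phenyl of Compound 2

The compounds below may be only part of what the source reports. "The series", "measured", "known", "first", "only" and "open" are said of these compounds alone.

Compound 2 `Cc1ccccc1-c1cncc(OC[C@@H]2CCCN2C)c1` gives 1.1 nM in an assay on membranes from brain for binding affinity to Neuronal acetylcholine receptor; alpha4/beta2 (Rattus norvegicus) (a higher number here means a weaker inhibitor, a lower number a stronger inhibitor), the higher of the two numbers in hand: compound 1 `CN1CCC[C@H]1COc1cncc(-c2ccccc2)c1` gives 0.11 nM in this assay, and the step of a 10-fold higher number from compound 1 to compound 2 (1.00 log units; beyond the scatter) arose from a methyl in place of hydrogen on an aromatic carbon. Compound 3 `CN1CCC[C@H]1COc1cncc(-c2ccccc2C=O)c1` carries formyl in place of methyl on an aromatic carbon. Among the compounds with values here, only that single step bears on the new change, and it shows a modest loss for a group at this place. The formyl is expected to leave the number near that of compound 2 or somewhat higher, a step of a 1.6-fold higher number from compound 2 to compound 3 (0.21 log units; within the scatter). Compound 3 is therefore estimated at 1.8 nM, between 0.5 nM and 6 nM.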

Compound 3, inhibition constant: 0.56 nM
Compound 3: the middle estimate sits 3.2-fold (0.51 log units) above what was measured; the measured number falls inside the stated range.
By their numbers in this assay, from the lowest: compound 1; then compounds 3 and 2 (each within the scatter of the next).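

In this assay, formyl and methyl on this aromatic carbon cannot be told apart, with a 2.0-fold lower number from compound 2 to compound 3 (0.29 log units; within the scatter). Formyl in place of hydrogen still gives a 5.1-fold higher number from compound 1 to compound 3 (0.71 log units; beyond the scatter), so both groups tried here stand beyond the scatter from hydrogen, and the loss seen with methyl is not unique to it. No measurement at hand offers an explanation for this. On these data alone, it remains open whether an amine, a carboxylic acid or a longer chain at this place would stay near compound 3 or return towards compound 1.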